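Swapping the aryl group on a labdane-type acid

The compounds below may be only part of what the source reports. "The series", "measured", "known", "first", "only" and "open" are said of these compounds alone.

Among the compounds with values here, compound 2, with structure `CC(CC[C@H]1/C(=C/c2ccc([N+](=O)[O-])cc2)CC[C@H]2C(C)(C)CCC[C@]12C)CC(=O)O`, is the only member of this small set with an actual number: in a functional assay on MCF7 cells (Homo sapiens) for cytotoxicity, read by MTT assay, with a stated time of 72 h (a lower number here means a stronger inhibitor, a higher number a weaker inhibitor), compound 2 gives 124000 nM. Compound 1, `Cc1ccc(/C=C2\CC[C@H]3C(C)(C)CCC[C@]3(C)[C@H]2CCC(C)CC(=O)O)cc1`, reaches only a limit in this assay, where compound 1 gives > 200000 nM. Within the data shown here, the one measured step, an at least 1.6-fold lower number from compound 1 to compound 2 (0.20 log units; that floor lies within the scatter), therefore cannot be sized beyond (the limit of > 200000 nM in this assay, at which 1 of the 2 values shown sits). Compound 3, `COc1ccc(/C=C2\CC[C@H]3C(C)(C)CCC[C@]3(C)[C@H]2CCC(C)CC(=O)O)cc1OC`, carries the change (3,4-dimethoxyphenyl in place of 4-nitrophenyl on a double-bonded chain carbon bound to a double-bonded ring carbon). No measured step swaps an aryl substituent for another among these compounds apart from the one above, which changed a methyl to a nitro and stayed within the scatter; the expectation is a step from compound 2 to compound 3 of about a 1.0-fold higher number from compound 2 to compound 3 (0.02 log units; within the scatter), none beyond the scatter. Compound 3 is thus expected to give about 130000 nM in this assay, with a likely range from 50000 nM to 300000 nM.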

Compound 3, half-maximal inhibitory concentration: > 200000 nM
Compound 3: no number, only a limit; the forecaster's own chance of this, stated with the estimate: 35%; at least 1.5-fold (0.18 log units) between middle value and limit.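

The swap of 4-nitrophenyl for 3,4-dimethoxyphenyl on a double-bonded chain carbon bound to a double-bonded ring carbon gives an at least 1.6-fold higher number from compound 2 to compound 3 (0.20 log units; that floor lies within the scatter) in this assay. Within the data shown here, compound 3 thus joins compound 1 in reading only as a limit, so a second aryl group at this place has produced no further number, and compound 2 remains the only compound with one: the limit of > 200000 nM in this assay, at which 2 of the 3 values shown sit. The step between compound 1 and compound 3 cannot be read, as both values are limits.

Still open is whether compound 2 truly differs from compound 1 and compound 3, as none of the readable steps is shown to go beyond the scatter. Also open, as far as these compounds go, is what a phenyl group carrying an amine would give at this place.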